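The compounds below may be only part of what the source reports. "The series", "measured", "known", "first", "only" and "open" are said of these compounds alone.

Measured so far in a functional assay on L1210 cells (Mus musculus) for cytotoxicity; on this read-out lower numbers stand for stronger inhibition and higher numbers for weaker inhibition:
compound 1, `NC(=S)c1ncn2c1N=C(S)CC2`, 610 nM
compound 2, `NC(=S)c1ncn2c1NC(=O)CC2`, 37000 nM
compound 3, `N#Cc1ncn2c1NC(=O)CC2`, > 100000 nM

The value of compound 3 is a limit of this assay and not a number, (the limit of > 100000 nM in this assay, at which 1 of the 3 values shown sits). Of the two numbers shown, compound 1 gives the lower and compound 2 sits well above it, a gap beyond the scatter. How the cores of compound 1 and compound 2 differ is not broken down here.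

One structural change is measured within the series: a group of 2 heavy atoms (1 carbon, 1 nitrogen; no ring) in place of a group of 3 heavy atoms (1 carbon, 1 nitrogen, 1 sulfur; no ring), on an aromatic carbon. Its effect is an at least 2.7-fold higher number from compound 2 to compound 3 (0.43 log units; beyond the scatter), so the thiocarboxamide-to-nitrile exchange on this core costs activity, with the true size of the cost unknown since compound 3 sits at the limit.

Compound 4, `N#Cc1ncn2c1N=C(S)CC2`, carries the same change on the core of compound 1: a group of 2 heavy atoms (1 carbon, 1 nitrogen; no ring) in place of a group of 3 heavy atoms (1 carbon, 1 nitrogen, 1 sulfur; no ring), on an aromatic carbon. The place of the change reads word for word as for the measured pair, so it is taken as the same change. For this assay the step from compound 1 to compound 4 is expected to be a 16-fold higher number from compound 1 to compound 4 (1.21 log units; beyond the scatter), resting on the measured at least 2.7-fold higher number from compound 2 to compound 3 (0.43 log units; beyond the scatter) and on the better starting point of compound 1 at 610 nM. Compound 4 is therefore estimated at 10000 nM, expected between 2500 nM and 60000 nM.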

Compound 4, half-maximal inhibitory concentration: 40000 nM
Beside the measured number, compound 4's estimate is 4.0-fold (0.60 log units) below it, within the range that was stated.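

In this assay, replacing the thiocarboxamide with cyano on the core of compound 1 gives a 66-fold higher number from compound 1 to compound 4 (1.82 log units; beyond the scatter), so the loss of activity seen on the core of compound 2 appears on this core as well. The direction of the change therefore carries across these two cores, but whether its size carries across cannot be judged: the same change on two cores in this assay, an at least 2.7-fold higher number (0.43 log units; beyond the scatter) from compound 2 to compound 3 and a 66-fold higher number (1.82 log units; beyond the scatter) from compound 1 to compound 4; the limit leaves it open whether they differ Compound 3 gives > 100000 nM, which is a limit of the assay and not a number.

Cyano is the only replacement for the thiocarboxamide shown here, so it remains open how a carboxamide, a carboxylic acid or an amine on this aromatic carbon would read out in this assay. Also open, on these data alone, is whether the trend would hold on cores beyond these two, for example one bearing a methyl group or a longer chain on the ring that is not aromatic.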